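The source may report more compounds than this note shows. Statements on the series, on what has been measured and on what is new or still open speak of the compounds shown alone.

Measured compounds:
- Compound 1 `O=c1[nH]c2ccccc2cc1-c1nc2cc(Br)ccc2[nH]1` gives 11400 nM in a functional assay on SK-OV-3 cells (Homo sapiens) for cytotoxicity, read by MTT assay, with a stated time of 48 h; on this read-out lower numbers stand for stronger inhibition and higher numbers for weaker inhibition.
- Compound 2 `Cc1ccc2[nH]c(=O)c(-c3nc4cc(C)c(C)cc4[nH]3)cc2c1` reaches only a limit of the assay, > 100000 nM, in this assay.
- Compound 3 `Cc1ccc2[nH]c(=O)c(-c3nc4cc(Br)ccc4[nH]3)cc2c1` reaches only a limit of the assay, > 100000 nM, in this assay.

Compound 1 is the only one of the three with a real number; the other two stop at the limit of > 100000 nM in this assay, at which 2 of the 3 values shown sit. Going by the values given here, the single measured step runs from compound 1 to compound 3: an at least 8.7-fold higher number from compound 1 to compound 3 (0.94 log units; beyond the scatter), a change of methyl for hydrogen on the core. Compound 4 `O=c1[nH]c2ccccc2cc1-c1nc2cc(Cl)ccc2[nH]1` differs from compound 1 in a different place: chloro in place of bromo on an aromatic carbon. Among the compounds with values here, no measured step swaps one halogen for another, and the methyl step touches a different carbon, so it says nothing direct about this exchange. The change is small and like for like, as the difference shows. Within the data shown here, the step in this assay is therefore expected to be none beyond the scatter, in neither direction, with the wide range reflecting that no measured pair tests this swap. Compound 4 is expected to give about 12000 nM, within 4000 nM to 40000 nM. This estimate means a 1.1-fold higher number from compound 1 to compound 4 (0.02 log units; within the scatter), expected to stay inside the usual scatter.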

Compound 4, half-maximal inhibitory concentration: 10500 nM
Estimate against measurement, compound 4: 1.1-fold (0.06 log units) above; low and high end bracket the measured number.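

In this assay, going by these compounds alone, the exchange of bromo for chloro on this aromatic carbon gives a 1.1-fold lower number from compound 1 to compound 4 (0.04 log units; within the scatter) and is the first measured swap of one halogen for another. Within the data shown here, at this position, then, the two halogens cannot be told apart on this read-out, something the earlier compounds could not show, since their only step was methyl in place of hydrogen on a different carbon. Compound 1 and compound 4 both give real numbers, so the exchange leaves the compound within the measurable range of the assay, whereas the methyl step ended at a limit of the assay.

From the compounds shown here alone, with only two halogens compared, it stays open what a quite different group at this place would do, such as an amine, a carboxylic acid or a methoxy group, and the same holds for plain hydrogen. The true size of the methyl step also cannot be read, because the values of the compounds carrying methyl on the core stop at a limit: the limit of > 100000 nM in this assay, at which 2 of the 4 values shown sit.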